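Swapping the Stereocentre in a Nicotinic Receptor Binder

The compounds below may be only part of what the source reports. "The series", "measured", "known", "first", "only" and "open" are said of these compounds alone.

Measured compounds:
compound 1 `Fc1ccc(COc2cccc(-c3cn([C@@H]4CN5CCC4CC5)nn3)c2)cc1`: 537 nM
compound 2 `FCCCOc1cccc(-c2cn([C@@H]3CN4CCC3CC4)nn2)c1`: 1980 nM
compound 3 `FCCOc1cccc(-c2cn([C@@H]3CN4CCC3CC4)nn2)c1`: 1260 nM

In an assay on HEK293 cells for displacement of a labelled ligand from Neuronal acetylcholine receptor; alpha4/beta2 (Homo sapiens), read by scintillation counting, with a stated time of 120 min (a higher number here means a weaker inhibitor, a lower number a stronger inhibitor), compound 1 gives 537 nM, the lowest number of the three, and since the steps of a 2.3-fold higher number from compound 1 to compound 3 (0.37 log units; beyond the scatter) and a 3.7-fold higher number from compound 1 to compound 2 (0.57 log units; beyond the scatter) both lie beyond the scatter, compound 1 is the strongest inhibitor among the measured compounds.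

Compound 4 `Fc1ccc(COc2cccc(-c3cn([C@H]4CN5CCC4CC5)nn3)c2)cc1` has the same atoms and bonds as compound 1: the two compounds have the same atoms and bonds; at least one stereo element is drawn with a configuration in one of them and without one in the other: 1 of 3 stereo elements differ; a stereocentre at a saturated ring carbon is drawn S in compound 1 and R in compound 4. Every measured step instead swaps the group attached to the ether oxygen, so none of them bears on a change at a stereocentre, and the expectation for compound 4 rests on compound 1 alone with a deliberately wide range. Compound 4 is therefore expected to give 2500 nM, between 400 nM and 15000 nM, and the expected step of a 4.7-fold higher number from compound 1 to compound 4 (0.67 log units; beyond the scatter) reflects this uncertainty.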

Compound 4, inhibition constant: 6390 nM
The estimate for compound 4 lay 2.6-fold (0.41 log units) below the measured number; the measured number falls inside the stated range.
By their numbers in this assay, from the lowest: compound 1; then compounds 3 and 2 (each within the scatter of the next); then compound 4.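

Turning one stereocentre at a saturated ring carbon from S to R, with every atom and bond kept, gives a 12-fold higher number from compound 1 to compound 4 (1.08 log units; beyond the scatter) in this assay, a larger step than any among the earlier compounds, which changed only the group on the ether oxygen. The configuration at this one carbon therefore counts for more here than those swaps did. The link to this place rests on a single structural difference: the fact that one of compounds 1 and 4 is drawn with a defined configuration and the other without, at the place where they differ

The compounds shown leave open whether the same swap moves the number as far in compound 2 or compound 3. They also leave open whether the S form keeps its lower number with an amine or a carboxylic acid in place of the ether.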